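From Three Unstable Compounds to a Trifluoromethyl Variant

This account rests on a few compounds, and the source may have more. Where it says the series, first, only, none or still open, it means among the compounds named here.

Compound 1, `CCC(CC)C(=O)OCOC(=O)C1=C(S[C@@H]2CN[C@H](C(=O)Nc3cccc(C(=O)O)c3)C2)[C@H](C)[C@@H]2[C@@H]([C@@H](C)O)C(=O)N12`: 0%
Compound 2, `CC(C)OC(=O)C1=C(S[C@@H]2CN[C@H](C(=O)Nc3cccc(C(=O)OC(C)C)c3)C2)[C@H](C)[C@@H]2[C@@H]([C@@H](C)O)C(=O)N12`: 0%
Compound 3, `CCOC(=O)C1=C(S[C@@H]2CN[C@H](C(=O)Nc3cccc(C(=O)OCC)c3)C2)[C@H](C)[C@@H]2[C@@H]([C@@H](C)OC(C)=O)C(=O)N12`: 0%

All three measured compounds were tested in an ADME assay on a cell-free system (plasma, Rattus norvegicus) for metabolic stability, read by LC-MS, with a stated time of 60 min, at 37 degrees C, tested at 50 uM; on this read-out lower numbers stand for a less stable compound and higher numbers for a more stable compound. Compound 1 gives 0%, compound 2 gives 0% and compound 3 gives 0%. Compound 1 therefore stands level with compounds 2 and 3 at the digits shown; nothing separates the three beyond the usual scatter, so no compound can be called more or less stable than another. Among the measured compounds shown here, no pair of measured compounds differs in a single place, so no measured step is available to guide an expectation.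

The unmeasured compound 4, `C[C@@H](O)[C@H]1C(=O)N2C(C(=O)OCC(F)(F)F)=C(S[C@@H]3CN[C@H](C(=O)Nc4cccc(C(=O)O)c4)C3)[C@H](C)[C@H]12`, departs from compound 1 by one change: trifluoromethyl in place of ((pentan-3-yl)carbonyl)oxy on a saturated chain carbon bound to an oxygen next to a carbonyl group. The group that leaves carries a carbonyl and two oxygens; the group that enters carries only a carbon and three fluorines.

For the measured compounds named here, with no measured step to rest on, the expected step from compound 1 to compound 4 is a number 20 percentage points higher from compound 1 to compound 4 (beyond the scatter), a rise of moderate size with wide uncertainty. Compound 4 is estimated at 20%, with a range from 0% to 60%.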

Compound 4, percent of the compound remaining: 7%
Compound 4: middle estimate off by 13 percentage points, on the high side; the measured number falls inside the stated range.
By their numbers in this assay, from the lowest: compounds 1, 2, 3 and 4 (each within the scatter of the next).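

In this assay, among the compounds shown here, putting trifluoromethyl in place of ((pentan-3-yl)carbonyl)oxy on a saturated chain carbon bound to an oxygen next to a carbonyl group gives a number 7 percentage points higher from compound 1 to compound 4 (within the scatter), the first comparison here in which only one place differs. This position can therefore take a group of four heavy atoms instead of one of eight, with no change in the reading that stands clear of the usual scatter. Nothing measured here explains this reading.

On these data alone, whether any group at this place can lift the reading clear of the scatter stays open, for example a longer chain carrying fluorine or a chain ending in an amine. As far as these compounds go, it is also open whether the same swap would give a similar result on a compound with a different group on the shared core.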